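The source may hold more compounds than are shown below. What is called first, only, known or untested is meant among the compounds shown, and "the series" means these compounds.

Compound 2, `CCc1nnc(SC)n1N1C(=O)c2ccccc2C1=O`, has been tested in a functional assay on PC-3M cells (Homo sapiens) for cytotoxicity, read by MTT assay, with a stated time of 48 h; a lower number here means a stronger inhibitor, a higher number a weaker inhibitor. Its result there is a limit of the assay rather than a number: in this assay compound 2 gives > 200000 nM. Compound 1, `CCOC(=O)CSc1nnc(C)n1N1C(=O)c2ccccc2C1=O`, likewise reaches only a limit in this assay, where compound 1 gives > 200000 nM. Going by the values given here, both readings therefore sit at the limit of > 200000 nM in this assay, at which 2 of the 2 values shown sit, so neither compound gives a measurable number, and no step between two measured compounds can be drawn from them.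

Compound 3, `CCOC(=O)CSc1nnc(CC)n1N1C(=O)c2ccccc2C1=O`, has not yet been measured in this assay. It differs from compound 2 by ethoxycarbonyl in place of hydrogen on a saturated chain carbon bound to a sulfur. The group that enters is the same one already present in compound 1, which itself reaches only a limit, so the change is not expected to bring the number into the measurable range. The step from compound 2 to compound 3 is therefore expected to be none beyond the scatter, written as a step that the limit leaves unreadable from compound 2 to compound 3. For compound 3 the estimate in this assay is 300000 nM, within a range from 100000 nM to 1000000 nM.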

Compound 3, half-maximal inhibitory concentration: > 200000 nM
Compound 3: no number, only a limit (the forecaster's own chance of this, stated with the estimate: 80%); the middle value does not contradict the limit.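

In this assay compound 1, compound 2 and compound 3 all give only a limit and no number, and the size of the steps among them cannot be read. The compounds shown leave open whether any change to the shared core or its side chains gives a measurable number in this assay at all.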